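Opening notes on the 2-aminobenzothiazole-type series in the rat

The source may report more compounds than this note shows. Statements on the series, on what has been measured and on what is new or still open speak of the compounds shown alone.

Measured compounds:
- compound 1, `C[Si](C)(C)c1ccc2nc(N)sc2c1`, 5 mg/kg
- compound 2, `CCCc1ccc2nc(N)sc2c1`, 6 mg/kg
- compound 3, `Cn1c(=N)sc2cc(OC(F)(F)F)ccc21`, 5 mg/kg

All three numbers come from a functional assay on the whole organism with Rattus norvegicus as the target; on this read-out lower numbers stand for an effect already at smaller amounts and higher numbers for an effect only at larger amounts of compound. In this assay, among the compounds with values here, compound 1 gives 5 mg/kg and compound 2 gives 6 mg/kg; the single step between them, a 1.2-fold higher number from compound 1 to compound 2 (0.08 log units; within the scatter), exchanges groups on an aromatic carbon. Compound 3 gives 5 mg/kg, level with compound 1 at the digits shown, and the gap to compound 2 is within the scatter as well, so no order among the three can be read from these values.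

Compound 4, `N=c1sc2cc(OC(F)(F)F)ccc2n1CCS(=O)(=O)O`, is not yet measured. It differs from compound 3 by sulfomethyl in place of hydrogen on a saturated chain carbon bound to an aromatic nitrogen. Within the data shown here, no measured step touches this position or this kind of group: the only step in hand, from compound 1 to compound 2, concerns an aromatic carbon. The expectation therefore rests on the level of compound 3 alone, with a wide range. For compound 4 the step of a 1.4-fold higher number from compound 3 to compound 4 (0.15 log units; within the scatter) is expected, that is an estimate of 7 mg/kg, between 2.5 mg/kg and 20 mg/kg.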

Compound 4, dose for half-maximal effect: > 10 mg/kg
Compound 4: a limit, no number; the forecaster's own chance of this, stated with the estimate: 15%; middle value at least 1.4-fold (0.15 log units) from the limit.
By their numbers in this assay, from the lowest: compounds 1, 3 and 2 (each within the scatter of the next). At a limit, above all of these: compound 4.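

In this assay compound 4 gives > 10 mg/kg, which is a limit of the assay and not a number. For sulfomethyl in place of hydrogen on a saturated chain carbon bound to an aromatic nitrogen, the step reads an at least 2.0-fold higher number from compound 3 to compound 4 (0.30 log units; that floor lies within the scatter), the only change shown at this position, and it gives a floor rather than a size. Unlike the step on the aromatic carbon, this one has no upper end, so it cannot yet be said whether the change reaches beyond the scatter: the limit of > 10 mg/kg in this assay, at which 1 of the 4 values shown sits.

Going by these compounds, how far the true value of compound 4 lies past this limit remains open. Also open is whether the outcome follows the sulfo group or the longer chain alone, as a plain ethyl, a carboxylic acid or an amine in this place is not among the compounds shown.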